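The source may report more compounds than this note shows. Statements on the series, on what has been measured and on what is new or still open speak of the compounds shown alone.

Measured so far in a functional assay on OVCAR-8 cells (Homo sapiens) for cytotoxicity, read by sulforhodamine B assay, with a stated time of 48 h; on this read-out lower numbers stand for stronger inhibition of growth and higher numbers for weaker inhibition of growth:
compound 1 `ClCc1ccc(Cn2cnc3nc(Cl)nc(Cl)c32)cc1` gives 4070 nM
compound 2 `ClCc1ccc(Cn2cnc3c(Cl)nc(Cl)nc32)cc1` gives 38000 nM
compound 3 `Nc1nc(Cl)c2ncn(Cc3cccc(CCl)c3)c2n1` gives 6760 nM

Of the three numbers, compound 1 holds the lowest. Its nearest neighbour is compound 3, whose number is higher but only by a margin that sits within the scatter of this assay, so no order can be read between the two. Among the compounds with values here, compound 2 is the far end of the set, with a number beyond the scatter above that of compound 1; the two values are all that is known of that pair, as no single-point step connects them.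

The next compound, compound 4 `ClCc1ccc(Cn2cnc3ncnc(Cl)c32)cc1`, is the one-place change from compound 1: hydrogen in place of chloro on an aromatic carbon. No step of this kind, a chloro removed from the core, has been measured within the series, so its size and direction cannot be taken from any pair shown. On the numbers available, the expectation is that compound 4 lands near compound 1 or somewhat higher, with the expected step of a 2.0-fold higher number from compound 1 to compound 4 (0.29 log units; within the scatter) small and possibly no larger than the scatter. The estimate for compound 4 in this assay is 8000 nM, with a range from 2500 nM to 25000 nM.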

Compound 4, concentration for total growth inhibition: 11000 nM
Compound 4: the middle estimate sits 1.4-fold (0.14 log units) below what was measured; measured number inside the range.
By their numbers in this assay, from the lowest: compounds 1, 3 and 4 (each within the scatter of the next, the first and the last beyond it); then compound 2.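

In this assay, within the data shown here, hydrogen in place of chloro on the aromatic carbon between two ring nitrogen atoms gives a 2.7-fold higher number from compound 1 to compound 4 (0.43 log units; beyond the scatter), the first single-place step, modest in size but beyond the scatter. This chloro therefore contributes to growth inhibition in the context of compound 1, yet it is not required for a measurable effect, since compound 4 still gives 11000 nM with the other chloro and the rest of the structure unchanged. No supporting measurement bears on why the step occurs, so it stands as an observation about this one position.

From the compounds shown here alone, only chloro and hydrogen have been compared on this carbon, so it remains open whether a methyl, a methoxy or a thioether there would give a number closer to that of compound 1 or compound 4. Going by these compounds, the contribution of the remaining chloro also stays open, and a single step in a single cell line cannot show whether the same change would have a similar effect on another scaffold or in other cells.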